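The source may report more compounds than this note shows. Statements on the series, on what has been measured and on what is new or still open speak of the compounds shown alone.

Compound 1 `CC[C@@H](Nc1c(C#N)c(-c2ccc(-c3cccc(C)c3)cc2)nc2cnccc12)C(N)=O` sits at the top of the three numbers in hand: in a physicochemical assay for lipophilicity, read by HPLC, at pH 7.5 (a higher number here means a more lipophilic compound, a lower number a more polar compound), compound 1 gives 3. Compound 2 `CCOc1ccccc1-c1ccc(-c2nc3cnccc3c(N[C@H](CC)C(=O)NS(=O)(=O)C3CC3)c2C#N)cc1` lies nearest to it, and in this assay compound 2 gives 2.3, a gap beyond the scatter. Compound 3 `CCOc1ccccc1-c1ccc(-c2nc3cnccc3c(N[C@H](CC)C(=O)NS(C)(=O)=O)c2C#N)cc1` lies furthest away; in this assay compound 3 gives 2.2. The only measured step that connects two of these compounds, a number 0.10 log units lower from compound 2 to compound 3 (within the scatter), concerns a methyl in place of a cyclopropyl on a sulfonyl sulfur, a site far from the change that leads to compound 4 `CC[C@@H](Nc1c(C#N)c(-c2ccc(-c3ccccc3COC)cc2)nc2cnccc12)C(N)=O`, and it is within the scatter, so it gives little direct guidance here.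

The change from compound 1 to compound 4 is 2-(methoxymethyl)phenyl in place of 3-methylphenyl on an aromatic carbon. The group that leaves carries no hydrogen-bond acceptor, whereas the group that enters carries one oxygen and one hydrogen-bond acceptor. Going by the values given here, no measured pair in this set shows the same exchange, so the expectation rests on the structural change alone, with the anchor of compound 1 at 3. The expected step is a drop beyond the scatter, a number 0.60 log units lower from compound 1 to compound 4 (beyond the scatter). For compound 4 the estimated value in this assay is 2.4, within a range from 1.9 to 2.9.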

Compound 4, distribution coefficient: 2.6
Compound 4: the middle estimate sits 0.20 log units below what was measured; measured number inside the range.
By their numbers in this assay, from the lowest: compounds 3, 2 and 4 (each within the scatter of the next, the first and the last beyond it); then compound 1.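

At this position, on an aromatic carbon para to a large group, the exchange of 3-methylphenyl for 2-(methoxymethyl)phenyl gives, in this assay, the only step among the compounds shown that lies beyond the scatter: a number 0.40 log units lower from compound 1 to compound 4 (beyond the scatter). Going by these compounds alone, the one earlier step sat at a sulfonyl sulfur and stayed within the scatter, whereas this pair shows that the number does respond to a change in this aromatic group, by a modest amount, when the entering group brings one oxygen and one hydrogen-bond acceptor. Nothing measured here accounts for the size of this step, and no supporting data bear on its origin.

The pair changes the oxygen, the chain and the place on the ring at once, so a partner such as 2-methylphenyl or 3-(methoxymethyl)phenyl would be needed to tell these apart. Also open, as far as these compounds go, are how an amine such as 2-(aminomethyl)phenyl or a carboxylic acid at this place would read, and whether the same exchange gives a similar step on the compounds that carry the sulfonyl group.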